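A few compounds are considered here, and "the series" means these few. Any claim that something is new, unique, unknown or untested is made for them only; others in the source may bear on it.

Three compounds of the series have so far been run in an ADME assay on RAW264.7 cells (Mus musculus) for cytotoxicity, read by MTT assay, with a stated time of 24 h, in the presence of a further agent that is not named here; a higher number here means a weaker inhibitor, a lower number a stronger inhibitor. Compound 1 `Cc1noc(CC2OC(=O)c3ccccc32)n1` gives no number there but only the assay limit, > 40000 nM. Compound 2 `O=C1OC(Cc2nc(-c3ccc(Oc4ccccc4)cc3)no2)c2ccccc21` likewise stops at the limit, > 40000 nM. Compound 3 `COc1cc(OC)c2c(c1)C(C(O)c1ccc(OCCOc3ccccc3)cc1)OC2=O`, the starting point for the step followed here, also gives a limit rather than a number, > 40000 nM. On the numbers shown compound 3 thus stands in a single place shared with the others: the limit of > 40000 nM in this assay, at which 3 of the 3 values shown sit, and no compound is shown to sit apart from any other beyond the scatter.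

Compound 4 `COc1cc(OC)c2c(c1)C(C(O)c1ccc(OCC3CCCCC3)cc1)OC2=O` has not yet been measured in this assay. It differs from compound 3 in one place (cyclohexyl in place of phenoxymethyl on a saturated chain carbon bound to an oxygen on an aromatic ring). Among the measured compounds shown here, no two measured compounds differ in one place, so no measured step exists from which the size of this change could be read. For the measured compounds named here, with every value so far a limit, the expectation is for no step beyond the scatter, and the change from compound 3 is expected to read as a number no higher from compound 3 to compound 4 (the limit leaves the size open). Compound 4 is accordingly estimated at 40000 nM, within 20000 nM to 80000 nM, with the most likely outcome that this assay once again reports only its limit.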

Compound 4, half-maximal inhibitory concentration: > 40000 nM
Compound 4 ended at the assay's limit; the forecaster's own chance of this, stated with the estimate: 85%; the middle value sits exactly at the limit.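

No step can be read from compound 3 to compound 4 in this assay, as both compounds report a limit and not a number. The compounds shown leave open how far any of them lies from the others and whether swapping phenoxymethyl for cyclohexyl changes anything, with all values in one place: the limit of > 40000 nM in this assay, at which 4 of the 4 values shown sit.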